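Removing One Methoxy Group from a Trimethoxyphenyl Pyrazole Chalcone

The compounds below may be only part of what the source reports. "The series", "measured", "known", "first", "only" and "open" are said of these compounds alone.

Measured compounds:
compound 1 `COc1ccc(-c2cc(/C=C/C(=O)c3ccc(N)cc3)[nH]n2)cc1`: -58%
compound 2 `COc1ccc(-c2cc(/C=C/C(=O)c3ccc(N)cc3)[nH]n2)cc1OC`: -53%
compound 3 `COc1cc(C(=O)/C=C/c2cc(-c3cc(OC)c(OC)c(OC)c3)n[nH]2)cc(OC)c1OC`: -95%

All three were tested in a functional assay on SW-620 cells (Homo sapiens) for cytotoxicity, read by sulforhodamine B assay, with a stated time of 48 h, tested at 100 uM; a lower number here means a stronger effect, a higher number a weaker effect of the compound at the concentration tested. Compound 1 and compound 2 share a core; the difference is hydrogen in place of methoxy on an aromatic carbon. The step of a number 5 percentage points lower from compound 2 to compound 1 (within the scatter) is within the scatter. Compound 3 is built on a different core, and the difference between the two cores is not broken down here; its value sits beyond the scatter from both compound 1 and compound 2.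

Compound 4 `COc1ccc(-c2cc(/C=C/C(=O)c3cc(OC)c(OC)c(OC)c3)[nH]n2)cc1OC` is not yet measured. It differs from compound 3 by hydrogen in place of methoxy on an aromatic carbon, the same kind of change as that from compound 2 to compound 1, though here the place is also meta to a methoxy group. Because the step of a number 5 percentage points lower from compound 2 to compound 1 (within the scatter) was small, compound 4 is expected to sit close to compound 3, with a step of about a number 5 percentage points higher from compound 3 to compound 4 (within the scatter). Compound 4 is estimated at -90%, with a range from -100% to -70%.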

Compound 4, a percentage reported as activity, at one concentration (the size of the read-out at that concentration, not a potency): -43%
Compound 4: middle estimate off by 47 percentage points, on the low side, and the stated range ends below it.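

In this assay, putting hydrogen in place of methoxy on an aromatic carbon gives a number 52 percentage points higher from compound 3 to compound 4 (beyond the scatter). The same kind of change therefore does not carry over from one core to the other in this series, and its small size on one core gave no guide to its size on the other: the same change on two cores in this assay, a number 5 percentage points lower (within the scatter) from compound 2 to compound 1 and a number 52 percentage points higher (beyond the scatter) from compound 3 to compound 4, 57 percentage points apart, beyond the scatter of two such steps

This rests on a single pair on each core, and it does not show what in the cores sets the size of the step, or how the change would behave on a further core. The compounds shown leave open whether a hydroxyl group or a chlorine atom at this place would keep the strong effect of compound 3. They also leave open whether losing a methoxy group from another place would cost as much.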